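Diaryl ureas with a dimethylpyrimidinyl linker: cytotoxicity notes

The source may report more compounds than this note shows. Statements on the series, on what has been measured and on what is new or still open speak of the compounds shown alone.

Measured so far:
compound 1, `Cc1cc(C)nc(Oc2ccc(NC(=O)Nc3ccc(OC(F)(F)F)cc3)cc2)n1`; in a functional assay on KB cells (Homo sapiens) for cytotoxicity, read by MTT assay, with a stated time of 3 days (on this read-out lower numbers stand for stronger inhibition and higher numbers for weaker inhibition), compound 1 gives 28900 nM
compound 2, `Cc1cc(C)nc(Oc2ccc(NC(=O)Nc3ccc(F)cc3)cc2)n1`; in this assay compound 2 gives 48400 nM
compound 3, `Cc1cc(C)nc(Sc2ccc(NC(=O)Nc3ccc(OC(F)(F)F)cc3)cc2)n1`; in this assay compound 3 gives 20000 nM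

The two cores differ as follows: (4,6-dimethylpyrimidin-2-yl)sulfanyl in place of (4,6-dimethylpyrimidin-2-yl)oxy on an aromatic carbon. The step that goes with this is a 1.4-fold lower number from compound 1 to compound 3 (0.16 log units; within the scatter), so compounds 1 and 3 cannot be told apart on this read-out. For the measured compounds named here, compound 2 gives a higher number than compound 3, and that gap lies beyond the scatter; no single-change step links them.

The change from compound 1 to compound 2 is fluoro in place of trifluoromethoxy on an aromatic carbon, and it made a 1.7-fold higher number from compound 1 to compound 2 (0.22 log units; within the scatter). The same change, at the same place, is now applied on the sulfanyl core: compound 4 `Cc1cc(C)nc(Sc2ccc(NC(=O)Nc3ccc(F)cc3)cc2)n1` differs from compound 3 by fluoro in place of trifluoromethoxy on an aromatic carbon.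

Compound 4 is expected to sit close to compound 3 in this assay, with a step of about a 1.7-fold higher number from compound 3 to compound 4 (0.23 log units; within the scatter), because the parallel step a 1.7-fold higher number from compound 1 to compound 2 (0.22 log units; within the scatter) stayed within the scatter and compound 3 starts from 20000 nM. The estimate for compound 4 is 34000 nM, within 17000 nM to 70000 nM.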

Compound 4, half-maximal inhibitory concentration: 32100 nM
Beside the measured number, compound 4's estimate is 1.1-fold (0.02 log units) above it; the measured number falls inside the stated range.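

In this assay, fluoro in place of trifluoromethoxy on the sulfanyl core gives a 1.6-fold higher number from compound 3 to compound 4 (0.21 log units; within the scatter). Set beside the same change on the oxy core, the two steps do not differ: the same change on two cores in this assay, a 1.7-fold higher number (0.22 log units; within the scatter) from compound 1 to compound 2 and a 1.6-fold higher number (0.21 log units; within the scatter) from compound 3 to compound 4, 1.0-fold (0.02 log units) apart, within the scatter of two such steps. So, within these two cores, the change carries over with no difference that this read-out can detect, but each step is itself within the scatter, so the agreement shows no clear effect of the change on either core, and one change on one pair of cores gives no rule for other changes or other cores.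

Only fluoro and trifluoromethoxy appear at this place, and only the oxy and sulfanyl links appear on the core. Going by these compounds, whether an amine or a carboxylic acid at this place, or an amine as the link, would give a step beyond the scatter, and whether such a step would carry from one core to the other, remains open.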